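Exchanging a Phenyl for a Pyridyl Ring

The source may report more compounds than this note shows. Statements on the series, on what has been measured and on what is new or still open speak of the compounds shown alone.

Compound 1, `CCCn1c(SCc2cc([N+](=O)[O-])ccc2OC)nc2cc(NC(=O)NC(C)(C)C)ccc21`: 18 nM
Compound 2, `CCCn1c(SCc2cc([N+](=O)[O-])ccc2OC)nc2cc(NC(=O)NC(C)(C)C)cc(C(=O)NCc3ccccc3)c21`: 120 nM

Of the compounds shown here, two have been measured in an assay on isolated protein for inhibition of Gonadotropin-releasing hormone receptor (Homo sapiens); on this read-out lower numbers stand for stronger inhibition and higher numbers for weaker inhibition. Compound 1 gives 18 nM. Among the measured compounds shown here, compound 2 gives 120 nM, the higher of the two numbers; the single measured step, a 6.7-fold higher number from compound 1 to compound 2 (0.82 log units; beyond the scatter), is the only comparison available. Compound 3, `CCCn1c(SCc2cc([N+](=O)[O-])ccc2OC)nc2cc(NC(=O)NC(C)(C)C)cc(C(=O)NCc3ccncc3)c21`, differs from compound 2 by pyridin-4-yl in place of phenyl on a saturated chain carbon bound to an amide-type nitrogen. That measured step concerns a different change at a different place, so it does not bear on the present exchange; nothing measured here tests a phenyl-to-pyridyl swap. Without such evidence, the expectation is a step that stays within the usual scatter, in no particular direction. Compound 3 is therefore estimated to give about 110 nM, with a range from 40 nM to 300 nM. The step this estimate means, a 1.1-fold lower number from compound 2 to compound 3 (0.04 log units; within the scatter), is expected to be small.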

Compound 3, half-maximal inhibitory concentration: 61 nM
For compound 3 the middle estimate is 1.8-fold (0.26 log units) above the measured one; low and high end bracket the measured number.
By their numbers in this assay, from the lowest: compound 1; then compounds 3 and 2 (each within the scatter of the next).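

Placing pyridin-4-yl in place of phenyl on the saturated chain carbon bound to the amide-type nitrogen gives a 2.0-fold lower number from compound 2 to compound 3 (0.29 log units; within the scatter), so in this assay this exchange, which brings in one hydrogen-bond acceptor, cannot be told apart from no change. The penalty for filling the aromatic carbon remains with the new group, as ((pyridin-4-yl)methyl)carbamoyl in place of hydrogen gives a 3.4-fold higher number from compound 1 to compound 3 (0.53 log units; beyond the scatter); thus both carbamoyl compounds shown, compound 2 and compound 3, carry higher numbers than compound 1. No measurement here gives a reason for either step.

Going by these compounds, it remains open whether pyridin-3-yl or pyridin-2-yl would behave like pyridin-4-yl at this place. Also open, on these data alone, is how a longer chain between the amide-type nitrogen and the ring, or a simple methylcarbamoyl, would compare with compound 1.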